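Ring in place of chain on the nitrogen substituent

The compounds below may be only part of what the source reports. "The series", "measured", "known", "first", "only" and "open" are said of these compounds alone.

In an assay on microsomes from liver for inhibition of sterol O-acyltransferase 1 (Rattus norvegicus) (a higher number here means a weaker inhibitor, a lower number a stronger inhibitor), compound 1 `CCCCn1nc(-c2ccccc2)c(-c2ccccc2)cc1=O` gives 176000 nM, compound 2 `CCCCCCn1nc(-c2ccccc2)c(-c2ccccc2)cc1=O` gives 57000 nM and compound 3 `CCCCCCCCCn1nc(-c2ccccc2)c(-c2ccccc2)cc1=O` gives 85000 nM. Compound 3 thus stands second highest of the three, nearest to compound 2, from which it is not separated beyond the scatter, and furthest from compound 1. Compound 4 `O=c1cc(-c2ccccc2)c(-c2ccccc2)nn1C1CCCC1` brings (cyclopentyl in place of nonyl on an aromatic nitrogen). The measured steps all alter the chain on that nitrogen: a 3.1-fold lower number from compound 1 to compound 2 (0.49 log units; beyond the scatter), a 2.1-fold lower number from compound 1 to compound 3 (0.32 log units; beyond the scatter) and a 1.5-fold higher number from compound 2 to compound 3 (0.17 log units; within the scatter); none covers a ring in place of a chain. Since lengthening the chain from compound 1 gave only modest changes and the step between compound 2 and compound 3 lies within the scatter, no step beyond the scatter is expected here no change at the digits printed from compound 3 to compound 4 (within the scatter). Compound 4 is therefore estimated at 85000 nM, within 30000 nM to 250000 nM.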

Compound 4, half-maximal inhibitory concentration: 119000 nM
The estimate for compound 4 lay 1.4-fold (0.15 log units) below the measured number, within the range that was stated.
By their numbers in this assay, from the lowest: compounds 2, 3, 4 and 1 (each within the scatter of the next, the first and the last beyond it).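

A ring on the aromatic nitrogen gives a number in the same range as the open chains in this assay, with a 1.4-fold higher number from compound 3 to compound 4 (0.15 log units; within the scatter) and a 1.5-fold lower number from compound 1 to compound 4 (0.17 log units; within the scatter) so cyclopentyl is not separated from nonyl or butyl. Only hexyl is separated from it, with a 2.1-fold higher number from compound 2 to compound 4 (0.32 log units; beyond the scatter) and this modest step is the one gap from cyclopentyl that exceeds the scatter. Open questions are how cyclohexyl, a chain longer than nonyl, or an amine or carboxylic acid at the end of the chain would read on this nitrogen. No supporting evidence bears on why these numbers fall as they do.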